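The source may report more compounds than this note shows. Statements on the series, on what has been measured and on what is new or still open speak of the compounds shown alone.

Working notes on the series. Among the measured compounds shown here, compound 1 `COc1ccccc1-c1c(C)nn(-c2nc(-c3ccc(Cl)c(Cl)c3)c(SC(C)C)s2)c1C(=O)O` gives 14700 nM in a functional assay on BJAB cells (Homo sapiens) for antiproliferative activity, with a stated time of 4 days (a lower number here means that less compound is needed, a higher number that more compound is needed for the effect), the lowest of the two numbers so far. Compound 2 `COC(=O)c1c(Cc2ccccc2[N+](=O)[O-])c(C)nn1-c1nc(-c2ccc(Cl)c(Cl)c2)c(SC(C)C)s1` gives 93000 nM, a gap from compound 1 that lies beyond the scatter. Compound 3 `Cc1c(-c2cc(Cl)cc(Cl)c2)c(C(=O)O)nn1-c1nc(-c2ccc3nccn3c2)c(SC(C)C)s1` is reported as "not active" (no number reported), with no number. For the measured compounds named here, no single-site step between measured compounds is available, so nothing connects the two numbers directly.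

Compound 4 `Cc1nn(-c2nc(-c3ccc(Cl)c(Cl)c3)c(SC(C)C)s2)c(C(=O)O)c1-c1ccccc1Cl` differs from compound 1 in one place: chloro in place of methoxy on an aromatic carbon. Chloro in place of methoxy, ortho to a large group, is a small exchange on the outer ring, and nothing measured here speaks for a shift in either direction. The expected step from compound 1 to compound 4 is a 1.0-fold higher number from compound 1 to compound 4 (0.01 log units; within the scatter), within the scatter. Compound 4 is estimated at 15000 nM, with a range from 5000 nM to 45000 nM.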

Compound 4, half-maximal effective concentration: 13100 nM
Compound 4: the middle estimate sits 1.1-fold (0.06 log units) above what was measured; the measured number falls inside the stated range.
By their numbers in this assay, from the lowest: compounds 4 and 1 (each within the scatter of the next); then compound 2.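

In this assay, among the compounds shown here, the change from 2-methoxyphenyl to 2-chlorophenyl gives a 1.1-fold lower number from compound 1 to compound 4 (0.05 log units; within the scatter), the first single-site step. At this position on the outer ring, therefore, chloro in place of methoxy leaves the number unchanged within the scatter, despite the loss of one hydrogen-bond acceptor and one heavy atom. No supporting measurement bears on why this step is flat.

Only these two substituents can be compared at this position, both leaving the number in the same range. As far as these compounds go, whether an amine, a hydroxyl or a longer alkoxy chain here would shift it remains open.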